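This account rests on a few compounds, and the source may have more. Where it says the series, first, only, none or still open, it means among the compounds named here.

Measured so far:
compound 1 `c1cc(N2CCCCC2)nc(Nc2ccc(Oc3ncnc4sccc34)cc2)n1` gives 66.3%
compound 2 `CNC(=O)c1cc(Oc2ccc(Nc3nccc(N4CCCCC4)n3)cc2)ccn1` gives 69.8%
compound 3 `c1cc(N2CCCCC2)nc(Nc2ccc(Oc3ncnc4ccsc34)cc2)n1` gives 61.5%

In a functional assay on HCT-116 cells (Homo sapiens) for inhibition, read by MTT assay, with a stated time of 72 h, tested at 20 uM (a lower number here means less inhibition, a higher number more inhibition at the concentration tested (going by the name of the read-out)), compound 2 has the highest of the three numbers, yet the steps of a number 3.5 percentage points higher from compound 1 to compound 2 (within the scatter) and a number 8.3 percentage points lower from compound 2 to compound 3 (within the scatter) both lie within the scatter, so the three compounds cannot really be told apart. Compound 4 `CNC(=O)c1cc(Oc2ccc(Nc3nccc(N4CCc5ccccc5C4)n3)cc2)ccn1` differs from compound 2 by 1,2,3,4-tetrahydroisoquinolin-2-yl in place of piperidin-1-yl on an aromatic carbon. Among the measured compounds shown here, every measured step so far changed the group on an oxygen on an aromatic ring, a different part of the shared core, so no measured step bears directly on this change; all three, including a number 4.8 percentage points lower from compound 1 to compound 3 (within the scatter), stayed within the scatter. With no direct guide, a step within the scatter is expected, a number 3.8 percentage points lower from compound 2 to compound 4 (within the scatter), though with wide uncertainty. Compound 4 is therefore estimated at 66%, in the range 42% to 86%.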

Compound 4, a percentage reported as inhibition, at one concentration (the size of the read-out at that concentration, not a potency): 31.2%
Estimate against measurement, compound 4: 34.8 percentage points above; the whole stated range lies above it.
By their numbers in this assay, from the lowest: compound 4; then compounds 3, 1 and 2 (each within the scatter of the next).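

In this assay, putting 1,2,3,4-tetrahydroisoquinolin-2-yl in place of piperidin-1-yl on the aromatic carbon gives a number 38.6 percentage points lower from compound 2 to compound 4 (beyond the scatter), the only step of this size among these compounds. This position therefore responds to its group, whereas the three steps changing the group on the oxygen did not separate the compounds. Nothing measured here accounts for the drop.

On these data alone, it remains open whether the added aromatic ring itself matters or simply the larger group. Also open, as far as these compounds go, is how a morpholin-4-yl or a benzylamino group would read at this position.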